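The source may hold more compounds than are shown below. What is called first, only, known or untested is meant among the compounds shown, and "the series" means these compounds.

The compounds measured so far:

Compound 1, `C=CCn1ncc2cnc(COC)n2c1=O`. In a functional assay for inhibition, with Homo sapiens as the target (on this read-out higher numbers stand for weaker inhibition and lower numbers for stronger inhibition), compound 1 gives > 48000 nM, which is a limit of the assay.
Compound 2, `C=CCn1ncc2cncn2c1=O`. In this assay compound 2 gives > 48000 nM, again a limit.
Compound 3, `COCc1ncc2cnnc(NCCN(C)C)n12`. In this assay compound 3 gives > 48000 nM, also a limit.

Compound 2 differs from compound 1 by hydrogen in place of methoxymethyl on an aromatic carbon, and the step that the two limits leave unreadable from compound 1 to compound 2 cannot be read, since both values sit at the limit of > 48000 nM in this assay, at which 3 of the 3 values shown sit. Compound 4, `CN(C)CCNc1nncc2cncn12`, has not yet been measured. It differs from compound 3 by hydrogen in place of methoxymethyl on an aromatic carbon, the same change at the same place as that from compound 1 to compound 2. The difference between the core of compound 3 and the core of compound 1 is not broken down here. Compound 4 is therefore expected to behave much like compound 3, with an expected value of 100000 nM, between 30000 nM and 500000 nM, most likely reported only as a limit. The expected step that the limit leaves unreadable from compound 3 to compound 4 rests on the earlier, unreadable step and on (the limit of > 48000 nM in this assay, at which 3 of the 3 values shown sit), where all three measured values sit.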

Compound 4, half-maximal inhibitory concentration: > 48000 nM
Compound 4: a limit, no number; the forecaster's own chance of this, stated with the estimate: 85%; the middle value is on the limit's open side.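

No step can be read from compound 3 to compound 4, because both values are limits of the assay: the limit of > 48000 nM in this assay, at which 4 of the 4 values shown sit.

The compounds shown leave open whether swapping methoxymethyl for hydrogen changes anything in this assay, as none gives a number there.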